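The compounds below may be only part of what the source reports. "The series", "measured", "known", "first", "only" and "open" are said of these compounds alone.

Of the compounds shown here, three built on one shared core have been measured. Compound 1 `OC(CCn1nc2c(Br)c(Br)c(Br)c(Br)c2n1)c1cccc(Br)c1` gives 1% in a functional assay on MCF7 cells (Homo sapiens) for antiproliferative activity, read by MTT assay, with a stated time of 24 h, tested at 100 uM (a lower number here means a stronger effect, a higher number a weaker effect of the compound at the concentration tested), compound 2 `COc1cccc(C(O)CCn2nc3c(Br)c(Br)c(Br)c(Br)c3n2)c1` gives 16%, and compound 3 `CC(O)CCn1nc2c(Br)c(Br)c(Br)c(Br)c2n1` gives 57%. Compound 3 thus stands highest of the three, the weakest effect at the tested concentration, and its steps to compound 2 and compound 1 both lie beyond the scatter. Compound 4 `OC(CCn1nc2c(Br)c(Br)c(Br)c(Br)c2n1)c1ccc(Cl)cc1` is not yet measured; it differs from compound 3 by 4-chlorophenyl in place of methyl on a saturated chain carbon bound to an oxygen on a saturated carbon and a saturated chain carbon. Within the data shown here, two measured steps bear on this change: a number 56 percentage points higher from compound 1 to compound 3 (beyond the scatter) and a number 41 percentage points higher from compound 2 to compound 3 (beyond the scatter), each putting methyl in place of a substituted phenyl on that carbon and raising the number strongly. Bringing a substituted phenyl back is therefore expected to lower the number by a large step, a number 51 percentage points lower from compound 3 to compound 4 (beyond the scatter). Compound 4 is expected to give 6%, within 0% to 25%.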

Compound 4, a percentage reported as activity, at one concentration (the size of the read-out at that concentration, not a potency): 0%
Compound 4: the middle estimate sits 6 percentage points above what was measured; the measured number falls inside the stated range.
By their numbers in this assay, from the lowest: compounds 4 and 1 (each within the scatter of the next); then compound 2; then compound 3.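

In this assay a third ring-bearing group on this saturated chain carbon, 4-chlorophenyl, again separates sharply from methyl (a number 57 percentage points lower from compound 3 to compound 4 (beyond the scatter)), so the large step also holds for a chlorine-bearing ring. The ring's substituent matters less, yet not nothing: 4-chlorophenyl and 3-bromophenyl cannot be told apart (a number 1 percentage points lower from compound 1 to compound 4 (within the scatter)), while 3-methoxyphenyl stands apart (a number 16 percentage points lower from compound 2 to compound 4 (beyond the scatter)). Nothing measured here gives a reason for these differences. Still open, going by these compounds, is how an unsubstituted phenyl, or a ring carrying an amine, would fare at this carbon.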